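The source may hold more compounds than are shown below. What is called first, only, known or untested is meant among the compounds shown, and "the series" means these compounds.

Compound 1 `COC[C@H]1O[C@H](OCCc2ccccc2)[C@H](NC(=O)CCCN)[C@H](OCc2ccc3ccccc3c2)[C@@H]1O`: > 10000 nM
Compound 2 `CS[C@@H]1O[C@H](COCc2ccccc2)[C@@H](O)[C@@H](OCc2ccc3ccccc3c2)[C@H]1NC(=O)CCN=C(N)N`: 180 nM
Compound 3 `CS[C@@H]1O[C@H](COCc2ccc(Cl)cc2)[C@@H](O)[C@@H](OCc2ccc3ccccc3c2)[C@H]1NC(=O)CCCN=C(N)N`: 720 nM

In an assay on CHO cells for displacement of a labelled ligand from somatostatin receptor type 4 (Homo sapiens) (a lower number here means a stronger inhibitor, a higher number a weaker inhibitor), compound 3 gives 720 nM, the highest of the two numbers shown, so it is the weaker binder of the pair. Compound 2 gives 180 nM, a lower number, and the gap lies beyond the usual scatter. Compound 1 returns only a limit, > 10000 nM, not a number. Compound 4 `CS[C@@H]1O[C@H](COCc2ccc(Cl)cc2)[C@@H](O)[C@@H](OCc2ccc3ccccc3c2)[C@H]1NC(=O)CCN` differs from compound 3 in one place: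

one nitrogen atom in place of a group of 5 heavy atoms (2 carbon, 3 nitrogen; no ring), on a saturated chain carbon, two bonds along the chain from a carbonyl carbon

Going by the values given here, no measured pair isolates this change. Compound 1 also carries an amino group on its chain yet differs from compound 3 in other places as well, so it cannot settle the matter. Compound 4 is expected to give 3000 nM, within 800 nM to 15000 nM. That expectation means a step of a 4.2-fold higher number from compound 3 to compound 4 (0.62 log units; beyond the scatter), toward weaker binding, with a real chance that only a limit is returned.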

Compound 4, half-maximal inhibitory concentration: 430 nM
For compound 4 the middle estimate is 7.0-fold (0.84 log units) above the measured one; measured number below the stated range.
By their numbers in this assay, from the lowest: compound 2; then compounds 4 and 3 (each within the scatter of the next). At a limit, above all of these: compound 1.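

Replacing the group of 5 heavy atoms with amino, on a saturated chain carbon, two bonds along the chain from a carbonyl carbon, gives a 1.7-fold lower number from compound 3 to compound 4 (0.22 log units; within the scatter) in this assay. In this pair, the larger group is therefore not needed for a measurable number, and the much smaller amino group serves equally well within the scatter. Nothing measured here explains this outcome. Going by these compounds, whether a carboxylic acid or a longer chain ending in amino would do the same at this position remains open.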